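The source may report more compounds than this note shows. Statements on the series, on what has been measured and on what is new or still open speak of the compounds shown alone.

Four compounds share an amide that joins two aromatic rings. Compound 1 `COc1cc(NC(=O)c2ccc(Cl)cc2)ccc1NS(C)(=O)=O` carries a methanesulfonamide and a methoxy group on one ring and a chloro group on the other. In an ADME assay on HEK293 cells (Homo sapiens) for cytotoxicity, read by MTT assay, with a stated time of 48 h (a higher number here means a weaker inhibitor, a lower number a stronger inhibitor), compound 1 sits at the limit (the limit of > 250000 nM in this assay, at which 1 of the 3 values shown sits), so its value > 250000 nM is a limit of the assay and not a number. Compound 2 `COc1cc(NC(=O)c2ccc(Cl)c([N+](=O)[O-])c2)ccc1NS(C)(=O)=O` differs from compound 1 in a single place: nitro in place of hydrogen on an aromatic carbon. In this assay compound 2 gives 164000 nM, which makes an at least 1.5-fold lower number from compound 1 to compound 2 (0.18 log units; that floor lies within the scatter). Compound 3 `O=C(Nc1ccc(NS(=O)(=O)C(F)(F)F)c(Cl)c1)c1ccc(Cl)cc1` is built on another core; the difference between the cores of compound 1 and compound 3 is not broken down here. In this assay compound 3 gives 191000 nM, and compound 2 and compound 3 lie within the scatter of each other. Within the data shown here, compound 4 `O=C(Nc1ccc(NS(=O)(=O)C(F)(F)F)c(Cl)c1)c1ccc(Cl)c([N+](=O)[O-])c1` has not been measured; it differs from compound 3 by the same change as the one between compound 1 and compound 2: nitro in place of hydrogen on an aromatic carbon. Among the measured compounds shown here, only one measured instance of this change exists, and it gives only a floor that lies within the scatter. For compound 4 in this assay the expected value is 120000 nM, with the likely range from 60000 nM to 250000 nM. For the measured compounds named here, that expectation amounts to a 1.6-fold lower number from compound 3 to compound 4 (0.20 log units; within the scatter), and it rests on the single earlier instance an at least 1.5-fold lower number from compound 1 to compound 2 (0.18 log units; that floor lies within the scatter) seen with compound 1 and compound 2.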

Compound 4, half-maximal inhibitory concentration: 228000 nM
Compound 4: middle estimate off by 1.9-fold (0.28 log units), on the low side, and the stated range covers the measured number.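

In this assay, nitro in place of hydrogen on an aromatic carbon gives a 1.2-fold higher number from compound 3 to compound 4 (0.08 log units; within the scatter), so on this core the change has no effect that can be told apart from the ordinary spread of repeated measurements. Setting this step beside the earlier one, on the core of compound 1, gives no firm comparison: the same change on two cores in this assay, an at least 1.5-fold lower number (0.18 log units; that floor lies within the scatter) from compound 1 to compound 2 and a 1.2-fold higher number (0.08 log units; within the scatter) from compound 3 to compound 4; the limit leaves it open whether they differ Compound 1 carries a limit of the assay and not a number, so the two cores show neither that the change carries over from one to the other with the same size nor that its size depends on the core: the limit of > 250000 nM in this assay, at which 1 of the 4 values shown sits.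

The compounds shown leave open what a different group would do in the place of the nitro group, such as an amine or a carboxylic acid, on either core. They also leave open whether the nitro change would give a step beyond the scatter on a further core, and a pair in which both compounds have a measured number rather than a limit would be needed to put a size on the change with any confidence.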